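The compounds below may be only part of what the source reports. "The series", "measured", "known", "first", "only" and "open" are said of these compounds alone.

Compound 1 `C=C[C@@](C)(/C=C/c1ccc(OC(C)=O)cc1)CCC=C(C)C`: 52%
Compound 2 `C=C[C@@](C)(/C=C/c1ccc(OC(=O)CCCCCCCCC)cc1)CCC=C(C)C`: 30%

In a functional assay on HEp-2 cells (Homo sapiens) for inhibition, with a stated time of 48 h, tested at 50 uM (a higher number here means more inhibition of growth at the concentration tested, a lower number less inhibition of growth), compound 1 stands highest of the two measured compounds at 52%. Compound 3 `C=C[C@@](C)(/C=C/c1ccc(OC)cc1)CCC=C(C)C` keeps the core of compound 1 and carries methyl in place of acetyl on an oxygen on an aromatic ring. Among the compounds with values here, the only measured step, a number 22 percentage points lower from compound 1 to compound 2 (beyond the scatter), is modest and lies beyond the scatter, but it is a different change, made on a saturated chain carbon bound to a carbonyl carbon. Within the data shown here, it therefore bears only indirectly, and no measured step covers acetoxy to methoxy. A smaller, slightly downward move is expected, an estimated a number 7 percentage points lower from compound 1 to compound 3 (within the scatter). The estimate for compound 3 is 45%, ranging from 25% to 62%.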

Compound 3, percent growth inhibition at one concentration: 40%
The estimate for compound 3 lay 5 percentage points above the measured number; the range from low to high includes it.
By their numbers in this assay, from the lowest: compounds 2 and 3 (each within the scatter of the next); then compound 1.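

In this assay, methyl in place of acetyl on the oxygen on the aromatic ring gives a number 12 percentage points lower from compound 1 to compound 3 (beyond the scatter), a modest step. Compound 3 still reaches 40%, so among these compounds, an acetyl on this oxygen is not needed for some inhibition of growth, although the number falls with its loss. No available evidence bears on why this step occurs. On these data alone, whether a free hydroxyl, an ethyl group or a longer ether chain on this oxygen would sit nearer compound 1 or compound 3 remains open.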